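Moving a fluorine around a pyridine ring in a series of antagonists

The compounds below may be only part of what the source reports. "The series", "measured", "known", "first", "only" and "open" are said of these compounds alone.

Of the compounds shown here, three in this set have been tested in an assay on HEK293 cells for antagonist activity at transient receptor potential cation channel subfamily V member 3 (Homo sapiens), read by FLIPR and calcium flux; a lower number here means a stronger inhibitor, a higher number a weaker inhibitor. Compound 1, `OC(c1ncccc1F)C1(c2ccc(Cl)c(Cl)c2)CCC1`, gives 610 nM in this assay and stands as the highest of the three numbers. Compound 3, `O[C@H](c1ccccn1)[C@]1(c2ccnc(C(F)(F)F)c2)C[C@@H](O)C1`, gives 530 nM, which lies within the scatter of compound 1. Compound 2, `O[C@H](c1ccccn1)[C@]1(c2ccc(Cl)c(Cl)c2)CCO1`, gives 150 nM, a lower number than compound 1 by a gap that lies beyond the scatter. Compound 2 and compound 3 each differ from compound 1 in more than one place, so no single step between measured compounds is shown.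

Compound 4, `OC(c1ccc(F)cn1)C1(c2ccc(Cl)c(Cl)c2)CCC1`, is not yet measured. It differs from compound 1 in one place: 5-fluoropyridin-2-yl in place of 3-fluoropyridin-2-yl on a saturated chain carbon bound to an oxygen on a saturated carbon and a saturated ring carbon. The two compounds share the same atoms, joined differently, so only the position of the fluorine on the pyridine ring is changed.

No step of this kind is shown among the measured compounds, so there is nothing to lean on beyond the value of compound 1. The author expects the step of a 1.2-fold lower number from compound 1 to compound 4 (0.09 log units; within the scatter) to be small, and most likely not beyond the scatter in either direction. For compound 4 the estimate in this assay is 500 nM, with a range from 180 nM to 1500 nM.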

Compound 4, antagonist equilibrium constant: 910 nM
Beside the measured number, compound 4's estimate is 1.8-fold (0.26 log units) below it; the range from low to high includes it.
By their numbers in this assay, from the lowest: compound 2; then compounds 3, 1 and 4 (each within the scatter of the next).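

In this assay, moving the fluorine around the pyridine ring gives a 1.5-fold higher number from compound 1 to compound 4 (0.17 log units; within the scatter), so 5-fluoropyridin-2-yl and 3-fluoropyridin-2-yl cannot be told apart at this place on the shared core. Going by these compounds alone, this is the first comparison in the set that changes one place only, and it isolates the position of the fluorine on the pyridine ring while the atoms stay the same; for these two placements on a saturated chain carbon bound to an oxygen on a saturated carbon and a saturated ring carbon, that position leaves no change readable beyond the scatter. Nothing measured alongside these compounds speaks to why the two read alike.

From the compounds shown here alone, it remains open whether the pyridine ring at this place would tolerate a larger change, such as a methoxy group, a nitrile or an amine in place of the fluorine. Also open, going by these compounds, is whether the same move of the fluorine would read alike on the core of compound 2 or on the core of compound 3, where the surroundings of the pyridine ring differ.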